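A few compounds are considered here, and "the series" means these few. Any claim that something is new, unique, unknown or untested is made for them only; others in the source may bear on it.

Compound 1 `COC(=O)C1=C(c2cc(Br)c(O)c(Br)c2)[C@](OC)(c2ccc(O)c(Br)c2)O[C@@]1(C(=O)OC)c1cc(Br)c(O)c(Br)c1`: > 10000 nM
Compound 2 `COC(=O)C1=C(c2cc(Br)c(O)c(Br)c2)C(=O)[C@](OC)(c2ccc(O)c(Br)c2)O[C@]1(OC)c1cc(Br)c(O)c(Br)c1`: > 10000 nM

In a functional assay on A549 cells (Homo sapiens) for cytotoxicity, read by sulforhodamine B assay, with a stated time of 72 h (on this read-out higher numbers stand for weaker inhibition and lower numbers for stronger inhibition), compound 1 gives > 10000 nM, which is a limit of the assay rather than a number. In this assay compound 2 gives > 10000 nM, likewise a limit. Both readings sit at the limit of > 10000 nM in this assay, at which 2 of the 2 values shown sit, so compound 1 stands at the edge of what the assay reports. Compound 3 `COC(=O)C1=C(c2cc(Br)c(O)c(Br)c2)[C@](OC)(c2cc(Br)c(O)c(Br)c2)O[C@@]1(C(=O)OC)c1cc(Br)c(O)c(Br)c1` differs from compound 1 by bromo in place of hydrogen on an aromatic carbon. Going by the values given here, no measured step between neighbouring compounds is known here. The step that the limit leaves unreadable from compound 1 to compound 3 is expected to be none beyond the scatter. Compound 3 is estimated at 15000 nM, between 5000 nM and 50000 nM, and is expected most likely to be reported again as a limit.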

Compound 3, half-maximal inhibitory concentration: > 10000 nM
Compound 3 ended at the assay's limit; the forecaster's own chance of this, stated with the estimate: 85%; the middle value lies beyond the limit too.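

Compound 1 and compound 3 are both reported only as limits in this assay, so no step can be read for going from 3-bromo-4-hydroxyphenyl to 3,5-dibromo-4-hydroxyphenyl. The compounds shown leave open which structural change, if any, would give a measurable value.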